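Series notes: triazole amide quinolines, cytotoxicity on colon cells

A few compounds are considered here, and "the series" means these few. Any claim that something is new, unique, unknown or untested is made for them only; others in the source may bear on it.

Measured compounds:
compound 1, `COc1cc2c(Oc3ccc(NC(=O)c4cn(-c5ccccc5C)nn4)cc3F)ccnc2cc1OCCCN1CCCC1`, 1200 nM
compound 2, `COc1cc2c(Oc3ccc(NC(=O)c4cn(-c5ccccc5C)nn4)cc3F)ccnc2cc1OCCCN1CCCCC1`, 1340 nM

Both compounds share one core and differ only in the amine at the end of the three-carbon chain on the aromatic oxygen. In a functional assay on HT-29 cells (Homo sapiens) for cytotoxicity, read by MTT assay, with a stated time of 72 h (a lower number here means a stronger inhibitor, a higher number a weaker inhibitor), compound 1 gives 1200 nM and compound 2 gives 1340 nM. The step of a 1.1-fold higher number from compound 1 to compound 2 (0.05 log units; within the scatter) is within the scatter, so the two numbers cannot be ordered. Within the data shown here, compound 2 stands as the higher of the two numbers, with compound 1 its only neighbour and within the scatter of it.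

Compound 3, `COc1cc2c(Oc3ccc(NC(=O)c4cn(-c5c(C)cccc5C)nn4)cc3F)ccnc2cc1OCCCN1CCCCC1`, is not yet measured. It differs from compound 2 by methyl in place of hydrogen on an aromatic carbon; cut one bond further out, the change reads 2-methylphenyl to 2,6-dimethylphenyl. Among the measured compounds shown here, no measured step touches this aromatic ring: the only step in hand, a 1.1-fold higher number from compound 1 to compound 2 (0.05 log units; within the scatter), concerns the amine on the chain and was within the scatter, so it gives no guide to the size or direction of a change on the aryl ring of the triazole.

For the measured compounds named here, with no comparable step available, the expectation for compound 3 in this assay is a number close to that of compound 2, with no step beyond the scatter assumed, a 1.1-fold higher number from compound 2 to compound 3 (0.05 log units; within the scatter), and a wide range to allow for the absence of precedent. Compound 3 is therefore estimated at 1500 nM, expected between 500 nM and 4500 nM.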

Compound 3, half-maximal inhibitory concentration: 3690 nM
For compound 3 the middle estimate is 2.5-fold (0.39 log units) below the measured one; the range from low to high includes it.
By their numbers in this assay, from the lowest: compounds 1 and 2 (each within the scatter of the next); then compound 3.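

Methyl in place of hydrogen on this aromatic carbon, ortho to a large group and meta to a methyl group, gives the first step in the series that lies beyond the scatter in this assay: a 2.8-fold higher number from compound 2 to compound 3 (0.44 log units; beyond the scatter). Among these compounds, this aromatic position therefore responds to a single added methyl, moving the number toward a weaker inhibitor, whereas the only earlier step, a 1.1-fold higher number from compound 1 to compound 2 (0.05 log units; within the scatter), at the amine on the chain, cannot be read as a change. Nothing at hand bears on the reason for the step on the aromatic ring.

On these data alone, whether this step belongs to methyl in particular stays open: one pair cannot show how fluorine, chlorine or methoxy on the same carbon would read, nor how the unsubstituted phenyl compares with 2-methylphenyl. Also open, as far as these compounds go, is whether 2,6-dimethylphenyl gives a step of similar size and direction when the chain ends in pyrrolidin-1-yl, as in compound 1, or in another amine such as morpholine.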